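Thienyl in place of methoxyphenyl on the amine nitrogen

The compounds below may be only part of what the source reports. "The series", "measured", "known", "first", "only" and "open" are said of these compounds alone.

Measured so far:
- compound 1 `CSc1ccc2c(c1)c(O)c(C(=S)N(C)c1ccccc1)c(=O)n2C`: 32% in a functional assay on the whole organism for inhibition, with Mus musculus as the target, at a dose of 10 mg/kg by the oral route; a lower number here means less inhibition, a higher number more inhibition at the dose given (going by the name of the read-out)
- compound 2 `COc1ccc(N(C)/C(S)=C2/C(=O)c3cc(Cl)ccc3N(C)C2=O)cc1`: 45% in this assay

Compound 2 holds the highest of the two numbers in this assay; the nearest, compound 1, lies lower by a gap beyond the usual scatter. For the measured compounds named here, no pair of measured compounds differs in a single place, so no step of any kind is available for comparison.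

Compound 3 `CN1C(=O)/C(=C(/S)N(C)c2cccs2)C(=O)c2cc(Cl)ccc21` has not yet been measured in this assay. It differs from compound 2 in one place: thiophen-2-yl in place of 4-methoxyphenyl on an amine nitrogen. Going by the values given here, nothing among the measured compounds shows what such an exchange does, so the expectation rests on the value of compound 2 alone. The step expected is a number 7 percentage points lower from compound 2 to compound 3 (within the scatter), a small loss, and one that may well stay within the scatter. Compound 3 is therefore expected to give about 38% in this assay, with an estimated range from 20% to 55%.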

Compound 3, a percentage reported as inhibition, in the whole organism at one dose (the size of the read-out at that dose, not a potency): 19%
Compound 3: middle estimate off by 19 percentage points, on the high side; measured number below the stated range.
By their numbers in this assay, from the lowest: compound 3; then compound 1; then compound 2.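

In this assay, the group on the amine nitrogen proves not to be interchangeable: thiophen-2-yl in place of 4-methoxyphenyl comes with a number 26 percentage points lower from compound 2 to compound 3 (beyond the scatter), the first single-place change readable in the series. The exchange replaces a six-membered aromatic ring of carbon only with a five-membered aromatic ring holding sulfur, and it removes the methoxy group in the same step, so these two changes cannot be told apart here. No measurement on hand bears on why the number falls.

Still open, on these data alone, is whether the loss follows the ring or the methoxy group; a plain phenyl on this nitrogen, on the core of compound 2, would separate the two. Also open, as far as these compounds go, is how a pyridin-3-yl or a saturated cyclohexyl would fare at this position.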